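Removing the Ortho Fluoro From Compound 2

A few compounds are considered here, and "the series" means these few. Any claim that something is new, unique, unknown or untested is made for them only; others in the source may bear on it.

Compound 2 `O=C(/C=C/c1ccccc1)c1ccc(N2CCN(c3ccccc3F)CC2)cc1` stands lowest of the three measured compounds in a functional assay on the whole organism (strain Kunming) for inhibition, with Mus musculus as the target, with a stated time of 1 h, at a dose of 40 mg/kg by the oral route (a lower number here means less inhibition, a higher number more inhibition at the dose given (going by the name of the read-out)), with 0.57%. Compound 1 `O=C(/C=C/c1ccccc1)c1ccc(N2CCN(c3ccc([N+](=O)[O-])cc3)CC2)cc1` gives 55.4% and compound 3 `O=C(/C=C/c1ccccc1)c1ccc(N2CCN(c3cccc(Cl)c3Cl)CC2)cc1` gives 30.7%. Compound 4 `O=C(/C=C/c1ccccc1)c1ccc(N2CCN(c3ccccc3)CC2)cc1` differs from compound 2 by hydrogen in place of fluoro on an aromatic carbon. Within the data shown here, no measured step removes a fluoro; the nearest are a number 30.1 percentage points higher from compound 2 to compound 3 (beyond the scatter) and a number 54.8 percentage points lower from compound 1 to compound 2 (beyond the scatter), both swaps of one aryl group for another, showing that the aryl group on the amine nitrogen moves the read-out widely. Since compound 2 sits near the floor, a rise rather than a fall is expected, but its size is uncertain because a number 30.1 percentage points higher from compound 2 to compound 3 (beyond the scatter) involves a different group. Compound 4 is estimated at 15% (range 0% to 40%), a step of a number 14.4 percentage points higher from compound 2 to compound 4 (beyond the scatter).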

Compound 4, a percentage reported as inhibition, in the whole organism at one dose (the size of the read-out at that dose, not a potency): 3.71%
Estimate against measurement, compound 4: 11.3 percentage points above; measured number inside the range.
By their numbers in this assay, from the lowest: compounds 2 and 4 (each within the scatter of the next); then compound 3; then compound 1.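

In this assay, taking away the fluoro changes nothing that can be told apart, a number 3.1 percentage points higher from compound 2 to compound 4 (within the scatter), so fluoro and hydrogen read alike at this place on the ring. The unsubstituted phenyl also stays at the low end, with a number 27 percentage points lower from compound 3 to compound 4 (beyond the scatter) and a number 51.7 percentage points lower from compound 1 to compound 4 (beyond the scatter), so the higher numbers go with the 2,3-dichlorophenyl and 4-nitrophenyl groups, while 2-fluorophenyl shows that not every substituent raises the number. Nothing shown explains these differences. As far as these compounds go, it remains open whether a methoxy group or an amine on this ring would read like fluoro or like nitro.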